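This account rests on a few compounds, and the source may have more. Where it says the series, first, only, none or still open, it means among the compounds named here.

Compound 1 `CN(C)C(=O)c1ccncc1Nc1cc(-c2ccc3ccn(C)c3c2)c2nccnc2c1`: 0.35 h
Compound 2 `CC(=O)N1CCC(NC(=O)c2ccncc2Nc2cc(-c3ccc4ccn(C)c4c3)c3nccnc3c2)CC1`: 0.117 h
Compound 3 `CN1CC(NC(=O)c2ccncc2Nc2cc(-c3ccc4ccn(C)c4c3)c3nccnc3c2)CCC1=O`: 0.75 h

In an ADME assay on microsomes from liver (Mus musculus, strain CD-1) for metabolic stability, read by LC-MS, tested at 2 uM (on this read-out higher numbers stand for a longer-lived compound and lower numbers for a shorter-lived compound), compound 3 gives 0.75 h, the highest of the three numbers. Compound 1 lies nearest to it and compound 2 furthest from it. The next compound to be measured is compound 4 `Cn1ccc2ccc(-c3cc(Nc4cnccc4C(=O)NCC4COCCN4)cc4nccnc34)cc21`. It keeps the core of compound 3 and differs only on the amide-type nitrogen: (morpholin-3-yl)methyl in place of 1-methyl-6-oxopiperidin-3-yl on an amide-type nitrogen.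

All three measured steps changed the group at this same place, so they are the best available guide. The number moved in both directions, with a 2.1-fold higher number from compound 1 to compound 3 (0.33 log units; beyond the scatter) and a 3.0-fold lower number from compound 1 to compound 2 (0.48 log units; beyond the scatter). The largest change was a 6.4-fold higher number from compound 2 to compound 3 (0.81 log units; beyond the scatter). Changes here can therefore go beyond the scatter, but their direction is hard to foresee, and no measured compound carries the (morpholin-3-yl)methyl group.

Compound 3 sits at the top of this small set, at 0.75 h, and so a fall looks likelier than a further rise, though a rise cannot be ruled out. The expected change is modest: a 2.5-fold lower number from compound 3 to compound 4 (0.40 log units; beyond the scatter). For compound 4 the estimated half-life is 0.3 h, with an expected range of 0.1 h to 0.85 h.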

Compound 4, half-life: > 1 h
Compound 4 was reported as a limit; the forecaster's own chance of this, stated with the estimate: 5%; at least 3.3-fold (0.52 log units) between middle value and limit.
By their numbers in this assay, from the lowest: compound 2; then compound 1; then compound 3. At a limit, above all of these: compound 4.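

In this assay compound 4 is reported as a limit and not as a number: the limit of > 1 h in this assay, at which 1 of the 4 values shown sits. Set against two of the earlier compounds, the (morpholin-3-yl)methyl group gives a gap that the earlier steps could not show, with an at least 8.5-fold higher number from compound 2 to compound 4 (0.93 log units; beyond the scatter) and an at least 2.8-fold higher number from compound 1 to compound 4 (0.45 log units; beyond the scatter), so this amide-type nitrogen can carry a group that stands well clear of both the 1-acetylpiperidin-4-yl and the dimethylamino compounds. Against the best earlier compound the reading is weaker, with an at least 1.3-fold higher number from compound 3 to compound 4 (0.12 log units; that floor lies within the scatter), so the two cannot be put in order, although replacing 1-methyl-6-oxopiperidin-3-yl with (morpholin-3-yl)methyl clearly brought no fall in half-life.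

From the compounds shown here alone, how far compound 4 really lies past its limit stays open, and with it the true size of all three steps. Also open, going by these compounds, is which part of the new group carries the result, a question that close relatives such as (piperidin-3-yl)methyl, with carbon in place of the ring oxygen, or 2-(morpholin-3-yl)ethyl, with a longer chain, could help to settle.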